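Quinolinone oximes and hydrazones: working notes

The compounds below may be only part of what the source reports. "The series", "measured", "known", "first", "only" and "open" are said of these compounds alone.

Measured compounds:
- compound 1 `O=c1[nH]c2ccccc2cc1/C=N/O`: 31800 nM
- compound 2 `Cc1ccc2[nH]c(=O)c(/C=N/O)cc2c1`: 38900 nM
- compound 3 `Cc1ccc2[nH]c(=O)c(/C=N/Nc3ccccc3)cc2c1`: 8470 nM

In a functional assay, read by spectrophotometry, with a stated time of 3 min (a higher number here means a weaker inhibitor, a lower number a stronger inhibitor), compound 1 gives 31800 nM, and compound 2 gives 38900 nM. The change between them is hydrogen in place of methyl on an aromatic carbon, and it made the step of a 1.2-fold lower number from compound 2 to compound 1 (0.09 log units; within the scatter). Compound 3 carries a different core from compound 2: the difference is anilino in place of hydroxy on a double-bonded nitrogen, and it made the step of a 4.6-fold lower number from compound 2 to compound 3 (0.66 log units; beyond the scatter). Compound 3 stands lowest of the three in this assay; its gaps to compound 1 and compound 2 are beyond the scatter.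

Compound 4 `O=c1[nH]c2ccccc2cc1/C=N/Nc1ccccc1` has not been measured. It differs from compound 3 by hydrogen in place of methyl on an aromatic carbon, the same change as between compound 2 and compound 1, at a place described in the same words. On the core of compound 2 that change gave a 1.2-fold lower number from compound 2 to compound 1 (0.09 log units; within the scatter), a step within the scatter. Compound 4 is therefore expected to sit close to compound 3, with an estimated step of a 1.1-fold lower number from compound 3 to compound 4 (0.05 log units; within the scatter), resting on compound 1 and compound 2 having shown a 1.2-fold lower number from compound 2 to compound 1 (0.09 log units; within the scatter). The estimate for compound 4 in this assay is 7500 nM, expected between 3500 nM and 16000 nM.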

Compound 4, half-maximal inhibitory concentration: 11800 nM
For compound 4 the middle estimate is 1.6-fold (0.20 log units) below the measured one; the range from low to high includes it.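

In this assay, hydrogen in place of methyl on an aromatic carbon gives a 1.4-fold higher number from compound 3 to compound 4 (0.14 log units; within the scatter), so on this second core too the step does not leave the scatter. Set beside the earlier step, the two cores cannot be told apart for this change: the same change on two cores in this assay, a 1.2-fold lower number (0.09 log units; within the scatter) from compound 2 to compound 1 and a 1.4-fold higher number (0.14 log units; within the scatter) from compound 3 to compound 4, 1.7-fold (0.23 log units) apart, within the scatter of two such steps This supports carrying the change between the core of compound 2 and the core of compound 3 at this one place, but with both steps this small it does not show that they are identical, nor that the same would hold on any other core or at any other place.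

The compounds shown leave open whether a different group on this aromatic carbon, such as methoxy, chlorine or a longer chain, would give a step beyond the scatter. They also leave open how the anilino group responds to a substituent on its own ring, such as an amine or a carboxylic acid.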